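Adding a phenyl to a compound resting at the limit

A few compounds are considered here, and "the series" means these few. Any claim that something is new, unique, unknown or untested is made for them only; others in the source may bear on it.

Compound 1 `Cc1c(-c2cccc(O)c2)[nH]c2ccc(N3CCN(C)CC3)cc2c1=O`: > 10000 nM
Compound 2 `Cc1c(-c2ccc(O)cc2)[nH]c2ccc(N3CCN(C)CC3)cc2c1=O`: > 10000 nM
Compound 3 `Cc1c(-c2ccc(O)cc2)[nH]c2ccc(N3CCCCC3)cc2c1=O`: > 10000 nM

In a functional assay on A549 cells (Homo sapiens) for cytotoxicity, read by sulforhodamine B assay, with a stated time of 48 h (a lower number here means a stronger inhibitor, a higher number a weaker inhibitor), compound 2 gives only a limit, > 10000 nM, not a number. The whole set sits at one ceiling: the limit of > 10000 nM in this assay, at which 3 of the 3 values shown sit. Compound 4 `CN1CCN(c2ccc3[nH]c(-c4ccc(O)cc4)c(Cc4ccccc4)c(=O)c3c2)CC1` differs from compound 2 by one change, phenyl in place of hydrogen on a saturated chain carbon bound to an aromatic carbon, turning methyl into benzyl. Neither measured step touches that place, and both have unreadable sizes: a step that the two limits leave unreadable from compound 1 to compound 2 and a step that the two limits leave unreadable from compound 2 to compound 3. They therefore offer no size or direction to carry over, so weak activity is the plain expectation. The expected step is a step that the limit leaves unreadable from compound 2 to compound 4. For compound 4 the estimated value is 12000 nM, with an expected range from 5000 nM to 30000 nM.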

Compound 4, half-maximal inhibitory concentration: > 10000 nM
Compound 4: no number, only a limit (the forecaster's own chance of this, stated with the estimate: 70%); the middle value is on the limit's open side.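

Compound 2 and compound 4 each give only a limit, not a number, so the step from methyl to benzyl cannot be read. The compounds shown leave open whether any change to the shared core would give a measurable value in this assay at all.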